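Isobutyl in Place of Isopropyl on Two Inactive Cores

The source may report more compounds than this note shows. Statements on the series, on what has been measured and on what is new or still open speak of the compounds shown alone.

Compounds 1 and 2 share one core, compounds 3 and 4 another. In a functional assay on RAW264.7 cells (Mus musculus) for inhibition, read by microscopy and resazurin assay, with a stated time of 72 h (a higher number here means a weaker inhibitor, a lower number a stronger inhibitor), compound 2 `COC(=O)[C@@H](NC(=O)c1ccc(/C=C2\SC(=O)N(CC(=O)NOCc3ccccc3)C2=O)cc1)C(C)C` gives > 128000 nM, which is a limit of the assay and not a number. Compound 1 `COC(=O)[C@H](CC(C)C)NC(=O)c1ccc(/C=C2\SC(=O)N(CC(=O)NOCc3ccccc3)C2=O)cc1` gives > 128000 nM in this assay, again only a limit. The change between them is isobutyl in place of isopropyl on a saturated chain carbon bound to an amide-type nitrogen and a carbonyl carbon, and the measured step is a step that the two limits leave unreadable from compound 2 to compound 1. Compound 3 `CC(C)[C@H](NC(=O)[C@H](C)NC(=O)c1cn(CC(=O)NOCc2ccccc2)c2ccccc12)C(=O)O` gives > 128000 nM in this assay, also a limit; how its core differs from that of compound 2 is not broken down here. Compound 4 `CC(C)C[C@H](NC(=O)[C@H](C)NC(=O)c1cn(CC(=O)NOCc2ccccc2)c2ccccc12)C(=O)O` carries the same kind of change, (isobutyl in place of isopropyl on a saturated chain carbon bound to an amide-type nitrogen and a carbonyl carbon), on the second core. Because every measured value sits at the limit of > 128000 nM in this assay, at which 3 of the 3 values shown sit, the step is expected to be a step that the limit leaves unreadable from compound 3 to compound 4 in this assay, most likely ending at the same limit. Compound 4 is estimated at 200000 nM, between 100000 nM and 500000 nM.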

Compound 4, half-maximal inhibitory concentration: > 128000 nM
Compound 4: no number, only a limit (the forecaster's own chance of this, stated with the estimate: 85%); the middle value lies beyond the limit too.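

Compound 3 and compound 4 both give only a limit, so no step can be read between them: the limit of > 128000 nM in this assay, at which 4 of the 4 values shown sit.

The compounds shown leave open whether isobutyl in place of isopropyl changes inhibition at all, on either core.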